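The source may hold more compounds than are shown below. What is called first, only, known or untested is meant among the compounds shown, and "the series" means these compounds.

Compound 1 `COc1cc(C)cc(-c2c(-c3ccnc(-c4ccc(C(C)=O)cc4)c3)cnn2CC#N)c1` carries acetyl on the outer aromatic ring of the shared core. In a functional assay on SF-295 cells (Homo sapiens) for inhibition, read by sulforhodamine B assay, with a stated time of 48 h (a higher number here means a weaker inhibitor of growth, a lower number a stronger inhibitor of growth), compound 1 gives only a limit, > 100000 nM, not a number. That is the boundary noted as the limit of > 100000 nM in this assay, at which 1 of the 3 values shown sits, so where compound 1 truly sits beyond it is not known.

The two measured neighbours differ from compound 1 in two places, the group on the outer ring and hydroxyl in place of methoxy on the other aryl. Compound 2 `Cc1cc(O)cc(-c2nn(CC#N)cc2-c2ccnc(-c3ccc(Oc4ccccc4)cc3)c2)c1`, with phenoxy, gives 21200 nM in this assay. Compound 3 `Cc1cc(O)cc(-c2nn(CC#N)cc2-c2ccnc(-c3ccc(N(C)C)cc3)c2)c1`, with dimethylamino, gives 8710 nM in this assay. Among the compounds with values here, the single step between them, a 2.4-fold lower number from compound 2 to compound 3 (0.39 log units; beyond the scatter), is the only measured change at the position in question, and it is modest.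

Compound 4 `COc1cc(C)cc(-c2c(-c3ccnc(-c4ccc(N(C)C)cc4)c3)cnn2CC#N)c1` is the untested analogue in which the change is dimethylamino in place of acetyl on an aromatic carbon. Within the data shown here, no measured step swaps acetyl for dimethylamino; the phenoxy-to-dimethylamino step gives only an indirect pointer, and nothing here tests methoxy against hydroxyl. Given that compound 1 stands only as a limit, a move to a measurable number is expected, in the direction of stronger growth inhibition, of size an at least 2.5-fold lower number from compound 1 to compound 4 (0.39 log units; beyond the scatter). Compound 4 is estimated at 40000 nM, within 10000 nM to 150000 nM.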

Compound 4, concentration for total growth inhibition: 315 nM
For compound 4 the middle estimate is 130-fold (2.10 log units) above the measured one; the whole stated range lies above it.
By their numbers in this assay, from the lowest: compound 4; then compound 3; then compound 2. At a limit, above all of these: compound 1.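

On the methoxy-bearing compounds, replacing 4-acetylphenyl with 4-(dimethylamino)phenyl, a single change at the outer ring, is enough to turn a compound with no measurable number into a strong growth inhibitor in this assay: an at least 310-fold lower number from compound 1 to compound 4 (2.50 log units; beyond the scatter). Compound 1 stays a limit, > 100000 nM, so the true size of this step is not known: the limit of > 100000 nM in this assay, at which 1 of the 4 values shown sits. Within the data shown here, the only earlier step at this position, a 2.4-fold lower number from compound 2 to compound 3 (0.39 log units; beyond the scatter), was modest and belonged to the hydroxyl compounds, whereas the new step is large and shows that, on this background, the group at this position can decide between a measurable number and none.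

From the compounds shown here alone, whether the gain comes from the dimethylamino group itself or from the loss of acetyl stays open, as does whether a primary amine, a morpholine or a methoxy group at the same place would keep it. Methoxy against hydroxyl on the other aryl also remains untested, since compound 3 and compound 4 differ in more than one place and give no clean comparison.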